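A few compounds are considered here, and "the series" means these few. Any claim that something is new, unique, unknown or untested is made for them only; others in the source may bear on it.

The study concerns four compounds that share one core and are compared in an assay on NK92 cells for inhibition of interleukin-2 (Homo sapiens), read by AlphaScreen, with stated times of 30 min and 1 h; a higher number here means a weaker inhibitor, a lower number a stronger inhibitor. Compound 1 `Cn1c(Cc2nn(C)c(=O)c3ccccc23)nnc1SCC(=O)Nc1ccc(Cl)cc1Cl` gives 7700 nM in this assay. Compound 2 `Cn1c(Cc2nn(C)c(=O)c3ccccc23)nnc1SCCCCCCCC(=O)Nc1ccc(Cl)cc1Cl` gives 350 nM in this assay, and of the two plain numbers shown, compound 2 holds the lower one. Compound 3 `Cn1nc(Cc2nnc(SCC(=O)Nc3ccc(Cl)cc3Cl)n2CCCO)c2ccccc2c1=O` reaches only a limit of this assay, reported as > 30000 nM. Among the measured compounds shown here, the one step measured at a single place is an at least 3.8-fold higher number from compound 1 to compound 3 (0.59 log units; beyond the scatter), and because its endpoint sits at the limit of > 30000 nM in this assay, at which 1 of the 3 values shown sits, the true size of that weakening is not known beyond its lower bound.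

Compound 4 `Cn1nc(Cc2nnc(SCCCCCCCC(=O)Nc3ccc(Cl)cc3Cl)n2CCCO[Si](C)(C)C(C)(C)C)c2ccccc2c1=O` has not yet been measured. It differs from compound 2 by a group of 10 heavy atoms (8 carbon, 1 oxygen, 1 silicon; no ring) in place of a hydrogen atom, on a saturated chain carbon bound to an aromatic nitrogen. For the measured compounds named here, this is the same place at which the change from compound 1 to compound 3 was made, so that step is the only measured guide; it weakened inhibition by at least a modest amount. Since the group entering compound 4 is larger than the 2-hydroxyethyl that entered compound 3, a weakening of at least similar size is expected, written as an 8.6-fold higher number from compound 2 to compound 4 (0.93 log units; beyond the scatter). Compound 4 is therefore estimated to give 3000 nM in this assay, with a range from 700 nM to 15000 nM.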

Compound 4, half-maximal inhibitory concentration: > 30000 nM
Compound 4: a limit, no number; the forecaster's own chance of this, stated with the estimate: 15%; at least 10-fold (1.00 log units) between middle value and limit.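

In this assay, the step seen on the short chain of compound 1 now has a counterpart on the longer chain of compound 2: an at least 85-fold higher number from compound 2 to compound 4 (1.93 log units; beyond the scatter), a large loss of inhibition. The earlier compounds shown here showed that this saturated chain carbon bound to an aromatic nitrogen accepts a 2-hydroxyethyl group poorly on one background only, whereas the same place now fails to tolerate a much larger group of 10 heavy atoms on the background with the lowest plain number, so the longer chain does not rescue substitution here, at least for these two groups. The two steps, an at least 3.8-fold higher number from compound 1 to compound 3 (0.59 log units; beyond the scatter) and the one to compound 4, differ in their entering group, and their sizes cannot be ranked, since each is only a lower bound set by the same assay limit: the limit of > 30000 nM in this assay, at which 2 of the 4 values shown sit.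

The compounds shown leave open whether a small group such as a single ethyl at this place would keep any of the inhibition of compound 2. They also leave open how a chain ending in an amine or a carboxylic acid would behave there.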